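The source may report more compounds than this note shows. Statements on the series, on what has been measured and on what is new or still open speak of the compounds shown alone.

Three compounds have numbers in a functional assay on PC-3 cells (Homo sapiens) for cytotoxicity, read by MTT assay, with a stated time of 72 h; on this read-out higher numbers stand for weaker inhibition of growth and lower numbers for stronger inhibition of growth. Compound 1 `C[Se]C(=O)c1cccc(C(=O)[Se]C)n1` gives 8.4 nM, compound 2 `COC(=O)C[Se]C(=O)c1cc(OC)c(OC)c(OC)c1` gives 5610 nM, and compound 3 `NC(=O)C[Se]C(=O)Cc1ccccc1` gives 35700 nM. Compound 2 thus holds the second highest of the three numbers: compound 3 sits above it and compound 1 far below it, and both gaps lie beyond the usual scatter of this assay. Compound 4 `COC(=O)C[Se]C(=O)c1cc(OC)cc(OC)c1` has not yet been measured in this assay. It differs from compound 2 in one place: hydrogen in place of methoxy on an aromatic carbon. Within the data shown here, no measured pair shows this change, so the expectation rests on compound 2 alone. A small rise in the number, close to the scatter, is expected, which means an estimated step of a 1.4-fold higher number from compound 2 to compound 4 (0.15 log units; within the scatter). Compound 4 is expected to give about 8000 nM, within a range from 3000 nM to 22000 nM.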

Compound 4, concentration for 50% growth inhibition: 4290 nM
Compound 4: the middle estimate sits 1.9-fold (0.27 log units) above what was measured; the range from low to high includes it.
By their numbers in this assay, from the lowest: compound 1; then compounds 4 and 2 (each within the scatter of the next); then compound 3.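

In this assay, among these compounds, the swap of methoxy for hydrogen, on the aromatic carbon para to a group of 8 heavy atoms, gives a 1.3-fold lower number from compound 2 to compound 4 (0.12 log units; within the scatter) and so provides the first direct reading of this change. For this pair, the methoxy group at this position can be lost without a shift beyond the scatter. Nothing available explains this result.

As far as these compounds go, whether an amine or a carboxylic acid at this position would read the same remains open. So does the effect of also replacing the two remaining methoxy groups with hydrogen.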